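The compounds below may be only part of what the source reports. "The series", "measured", "known", "first", "only" and "open" are said of these compounds alone.

Measured compounds in a functional assay on KBVIN cells (Homo sapiens) for cytotoxicity, read by MTT assay, with a stated time of 72 h; on this read-out lower numbers stand for an effect already at smaller amounts and higher numbers for an effect only at larger amounts of compound:

compound 1 `CCc1cccc2c(O)c(-c3occ(C)c3C(=O)O)ccc12`, 7 ug/mL
compound 2 `CCc1cccc2c(OC)c(-c3occ(C)c3CO)ccc12`, 6.6 ug/mL
compound 3 `CCOc1c(-c2occ(C)c2CO)ccc2c(CC)cccc12`, 6.4 ug/mL

In this assay compound 2 stands second highest of the three numbers; its nearest neighbour is compound 3, its furthest compound 1, and all three values lie within the scatter of one another. The unmeasured compound 4 `CCc1cccc2c(OC)c(-c3occ(C)c3COC(C)=O)ccc12` differs from compound 2 by acetyl in place of hydrogen on an oxygen on a saturated carbon. Among the compounds with values here, the only measured single-point step, a 1.0-fold lower number from compound 2 to compound 3 (0.01 log units; within the scatter), touches the oxygen on the aromatic ring, not the hydroxymethyl, so no measured step bears directly on the change to compound 4. With all three values within the scatter, no step beyond the scatter is expected for compound 4; the estimate is 6.5 ug/mL, range 3 ug/mL to 14 ug/mL. The expected step is a 1.0-fold lower number from compound 2 to compound 4 (0.01 log units; within the scatter).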

Compound 4, concentration for half-maximal effect: > 10 ug/mL
Compound 4: only a limit was reported; the forecaster's own chance of this, stated with the estimate: 5%; middle value at least 1.5-fold (0.18 log units) from the limit.
By their numbers in this assay, from the lowest: compounds 3, 2 and 1 (each within the scatter of the next). At a limit, above all of these: compound 4.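

Among the compounds shown, this is the only single-place change at the hydroxymethyl, and acetoxymethyl in place of hydroxymethyl in this assay gives an at least 1.5-fold higher number from compound 2 to compound 4 (0.18 log units; that floor lies within the scatter). Compound 4 stands at a limit and not at a number: the limit of > 10 ug/mL in this assay, at which 1 of the 4 values shown sits. The floor of the step lies within the scatter, so a real loss on acetylation is possible but not established.

Still open, from the compounds shown here alone, is how a methoxymethyl, an aminomethyl or a longer ester such as propionyloxymethyl would read here. Also open, going by these compounds, is whether acetoxymethyl reads the same with the ethoxy group of compound 3.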